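Dropping the chloro from compound 1: cytotoxicity still expected weak

This account rests on a few compounds, and the source may have more. Where it says the series, first, only, none or still open, it means among the compounds named here.

The study tests how strongly a small set of compounds kills cells in a functional assay on SK-N-SH cells (Homo sapiens) for cytotoxicity, read by MTT assay, with a stated time of 24 h; a higher number here means a weaker inhibitor, a lower number a stronger inhibitor. Compound 1 `CC1(C)OC2O[C@@H](Cc3cn4cc(Cl)ccc4nc3=O)C(OCc3ccccc3)C2O1` gives only a limit there: in this assay compound 1 gives > 1000000 nM, which is a limit of the assay rather than a number, and the limit of > 1000000 nM in this assay, at which 1 of the 3 values shown sits, tells that this is where it sits. Two other compounds give numbers. Compound 2 `O=c1nc2ccccn2cc1Cc1ccccc1` gives 95400 nM in this assay. Compound 3 `O=c1nc2ccc(Br)cn2cc1Cc1cccc(Oc2nc(Cl)c(Cl)cc2Cl)c1` gives 9240 nM in this assay. No two of these compounds differ in only one place, so no single step among them can be read.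

Compound 4 `CC1(C)OC2O[C@@H](Cc3cn4ccccc4nc3=O)C(OCc3ccccc3)C2O1` is the compound yet to be measured. It differs from compound 1 in one place: hydrogen in place of chloro on an aromatic carbon. Since compound 1 reaches only the limit in this assay, the step from compound 1 to compound 4 is expected to be small, with no direction beyond the scatter, and most likely compound 4 will again be reported as a limit. The expected step is a number no higher from compound 1 to compound 4 (the limit leaves the size open). Compound 4 is estimated at 1000000 nM in this assay, within a range from 200000 nM to 5000000 nM.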

Compound 4, half-maximal inhibitory concentration: > 1000000 nM
Compound 4: only a limit was reported; the forecaster's own chance of this, stated with the estimate: 70%; the middle value lies on the limit itself.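

Compound 1 and compound 4 both give only a limit of the assay, so no step between them can be read in this assay: the limit of > 1000000 nM in this assay, at which 2 of the 4 values shown sit.

The compounds shown leave open whether hydrogen in place of chloro on an aromatic carbon changes the value in this assay at all.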